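Swapping the Aryl Group on the Acyl Urea Arm

The compounds below may be only part of what the source reports. "The series", "measured", "known", "first", "only" and "open" are said of these compounds alone.

In a functional assay on MCF7 cells (Homo sapiens) for inhibition, read by MTT assay, with a stated time of 72 h (a higher number here means a weaker inhibitor, a lower number a stronger inhibitor), compound 2 `CN(C(=O)NC(=O)c1ccc([N+](=O)[O-])cc1)c1nc(C(F)(F)F)c(C(=O)N/N=C/c2cccc(C(F)(F)F)c2)s1` gives 4.39 ug/mL, the lower of the two numbers seen so far. Among the compounds with values here, its only measured neighbour is compound 1 `CN(C(=O)NC(=O)c1ccc(Cl)cc1Cl)c1nc(C(F)(F)F)c(C(=O)N/N=C/c2cccc(C(F)(F)F)c2)s1`, which in this assay gives 10.7 ug/mL; the change between them is a 2.4-fold lower number from compound 1 to compound 2 (0.39 log units; beyond the scatter). Compound 3 `CN(C(=O)NC(=O)c1cccc(C(F)(F)F)c1)c1nc(C(F)(F)F)c(C(=O)N/N=C/c2cccc(C(F)(F)F)c2)s1` is the next step: 3-(trifluoromethyl)phenyl in place of 4-nitrophenyl on a carbonyl carbon. Within the data shown here, no measured pair shows this particular swap. Among the measured compounds shown here, the one step known, a 2.4-fold lower number from compound 1 to compound 2 (0.39 log units; beyond the scatter), concerns a different pair of aryl groups on the same carbonyl carbon, so it says only that exchanging this group can shift the number beyond the scatter, not which way the new group will go. The expectation for compound 3 is therefore a cautious one, a step of a 1.6-fold higher number from compound 2 to compound 3 (0.20 log units; within the scatter) that stays within the scatter. Compound 3 is estimated at 7 ug/mL in this assay, with a range from 3 ug/mL to 17 ug/mL.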

Compound 3, half-maximal inhibitory concentration: 3.7 ug/mL
Beside the measured number, compound 3's estimate is 1.9-fold (0.28 log units) above it; the range from low to high includes it.
By their numbers in this assay, from the lowest: compounds 3 and 2 (each within the scatter of the next); then compound 1.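

In this assay, the new step, a 1.2-fold lower number from compound 2 to compound 3 (0.07 log units; within the scatter), shows that 4-nitrophenyl and 3-(trifluoromethyl)phenyl on this carbonyl carbon cannot be told apart, although the first brings nitrogen and oxygen with hydrogen-bond acceptors and the second brings fluorine with none. Compound 1, with its 2,4-dichlorophenyl, now stands apart from both others, as a 2.9-fold lower number from compound 1 to compound 3 (0.46 log units; beyond the scatter) joins the earlier 2.4-fold lower number from compound 1 to compound 2 (0.39 log units; beyond the scatter), so the position does respond to the aryl group, but only the 2,4-dichlorophenyl swaps have moved the number beyond the scatter. Nothing measured here explains why these groups compare as they do.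

As far as these compounds go, it remains open whether a bare phenyl ring would read like compound 2 and compound 3 or like compound 1. Also open, from the compounds shown here alone, is how this position would respond to an aryl ring carrying an amine or a carboxylic acid.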